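The source may report more compounds than this note shows. Statements on the series, on what has been measured and on what is new or still open speak of the compounds shown alone.

Measured compounds:
compound 1 `Cn1cccc1-c1cc(-c2cccs2)[nH]c(=O)c1C#N`, > 100000 nM
compound 2 `CC1CCCc2c1[nH]c(=O)c(C#N)c2-c1cccn1C`, > 100000 nM

Of the compounds shown here, two have been tested in a functional assay on SN12C cells (Homo sapiens) for inhibition, read by sulforhodamine B assay, with a stated time of 48 h; a lower number here means a stronger inhibitor of growth, a higher number a weaker inhibitor of growth. In this assay compound 1 gives > 100000 nM, which is a limit of the assay and not a number. Compound 2 gives > 100000 nM in this assay, and this too is a limit. Within the data shown here, compound 1 therefore stands at the limit of > 100000 nM in this assay, at which 2 of the 2 values shown sit; no actual number is known for it, and nothing among the measured values sets it apart from compound 2.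

Compound 3 `Cn1cccc1-c1cc(-c2ccccc2)[nH]c(=O)c1C#N` differs from compound 1 by phenyl in place of thiophen-2-yl on an aromatic carbon. Among the measured compounds shown here, no step between two measured compounds exists to show what such a change does here. Since compound 1 sits at the limit of > 100000 nM in this assay, at which 2 of the 2 values shown sit, the step from compound 1 to compound 3 is expected to be small, with no direction beyond the scatter, a step that the limit leaves unreadable from compound 1 to compound 3. Compound 3 is accordingly estimated at 150000 nM, within a range from 20000 nM to 1000000 nM, and most probably it will again be reported only as a limit.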

Compound 3, concentration for 50% growth inhibition: > 100000 nM
Compound 3: no number, only a limit (the forecaster's own chance of this, stated with the estimate: 85%); the middle value is on the limit's open side.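

In this assay compound 3 gives > 100000 nM, which is a limit of the assay and not a number. The change from compound 1 to compound 3 therefore cannot be read as a step of any size. The compounds shown leave open which change to the shared core, if any, would yield an actual number, as all of them stand at one point: the limit of > 100000 nM in this assay, at which 3 of the 3 values shown sit.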